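The source may report more compounds than this note shows. Statements on the series, on what has been measured and on what is new or still open speak of the compounds shown alone.

Of the compounds shown here, three of one family have been measured in a functional assay on HeLa cells (Homo sapiens) for cytotoxicity, read by MTT assay, with a stated time of 48 h, in the presence of a further agent that is not named here; a lower number here means a stronger inhibitor, a higher number a weaker inhibitor. Compound 1 `COc1ccc(NC(=O)c2csc(-c3cn(Cc4ccc(Cl)cc4)c4ccccc34)n2)cc1` gives 90900 nM, the highest of the three numbers. Compound 2 `COc1ccc(NC(=O)c2csc(-c3c[nH]c4ccc(F)cc34)n2)cc1` gives 33500 nM, and compound 3 `COc1cc(NC(=O)c2csc(-c3c[nH]c4ccc(F)cc34)n2)cc(OC)c1OC` gives 48900 nM. Compound 1 and compound 3 sit within the usual scatter of each other, while compound 2 stands beyond it.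

Compound 4 `COc1cc(NC(=O)c2csc(-c3cn(Cc4ccc(Cl)cc4)c4ccccc34)n2)cc(OC)c1OC` is not yet measured. It differs from compound 1 in one place: 3,4,5-trimethoxyphenyl in place of 4-methoxyphenyl on an amide-type nitrogen. Going by the values given here, no directly measured pair shows this change, so the expectation rests on the spread among compound 1, compound 2 and compound 3. No shift beyond the scatter is expected, so the step of a 1.2-fold higher number from compound 1 to compound 4 (0.08 log units; within the scatter) is estimated as small. Compound 4 is expected to give about 110000 nM in this assay, in a range from 45000 nM to 270000 nM.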

Compound 4, half-maximal inhibitory concentration: > 100000 nM
Compound 4: a limit, no number; the forecaster's own chance of this, stated with the estimate: 25%; the middle value does not contradict the limit.
By their numbers in this assay, from the lowest: compounds 2, 3 and 1 (each within the scatter of the next, the first and the last beyond it). At a limit, above all of these: compound 4.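

Placing 3,4,5-trimethoxyphenyl instead of 4-methoxyphenyl on the amide-type nitrogen can now be read directly on one shared core in this assay, and it gives an at least 1.1-fold higher number from compound 1 to compound 4 (0.04 log units; that floor lies within the scatter). Compound 4 reads > 100000 nM, which is a limit of the assay and not a number. On these data alone, the step is therefore only a floor, so this change shows no gain in potency, but its true size stays unknown.

Still open, as far as these compounds go, is how a phenyl ring carrying an amine or a carboxylic acid in place of the methoxy groups would read at this position.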